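The source may hold more compounds than are shown below. What is called first, only, known or untested is meant among the compounds shown, and "the series" means these compounds.

Measured so far:
- compound 1 `C=CC(=O)N1C(=O)CC(c2ccc(C(F)(F)F)cc2)Sc2ccccc21` gives 38600 nM
- compound 2 `C=CC(=O)N1C(=O)CC(c2ccc(Cl)cc2)Sc2ccccc21` gives 22600 nM

In a functional assay on NB-4 cells (Homo sapiens) for cytotoxicity, read by CCK-8 assay, with a stated time of 24 h (on this read-out lower numbers stand for stronger inhibition and higher numbers for weaker inhibition), compound 2 gives 22600 nM and sits within the usual scatter of compound 1 (38600 nM), so the two cannot be told apart. The next structure is compound 3 `C=CC(=O)N1C(=O)CC(c2cccs2)Sc2ccccc21`, which keeps the shared core and the vinylcarbonyl group. It carries thiophen-2-yl in place of 4-chlorophenyl on a saturated ring carbon in a change that swaps a whole ring. Among the compounds with values here, the only measured step that bears on this is a 1.7-fold lower number from compound 1 to compound 2 (0.23 log units; within the scatter) and it lies within the scatter. Within the data shown here, that step altered only a group on the ring, and no thiophene compound has been measured, so the guidance is thin. No step beyond the scatter is expected in this assay here. The expected step is a 1.1-fold higher number from compound 2 to compound 3 (0.04 log units; within the scatter) and it comes with wide uncertainty. For compound 3 the estimated value is 25000 nM with an expected range from 10000 nM to 60000 nM at its two ends.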

Compound 3, half-maximal inhibitory concentration: 765000 nM
The estimate for compound 3 lay 31-fold (1.49 log units) below the measured number; the whole stated range lies below it.
By their numbers in this assay, from the lowest: compounds 2 and 1 (each within the scatter of the next); then compound 3.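

In this assay, putting thiophen-2-yl in place of 4-chlorophenyl on the saturated ring carbon next to the ring sulfur gives a 34-fold higher number from compound 2 to compound 3 (1.53 log units; beyond the scatter), a step beyond the scatter. Compound 1 and compound 2 differ only in a group on the six-membered aromatic ring and cannot be told apart, whereas exchanging the whole ring shows that the read-out does depend strongly on what this carbon carries. Nothing in the data gives a cause for this large step.

Thiophen-2-yl differs from 4-chlorophenyl at once in ring size, in its ring sulfur and in lacking the chloro group, and this single step cannot separate those differences. On these data alone, how a plain phenyl or a furan-2-yl group at this carbon would read remains open.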